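Removing One Methoxy Group from Compound 1

The source may report more compounds than this note shows. Statements on the series, on what has been measured and on what is new or still open speak of the compounds shown alone.

In a functional assay on HeLa cells (Homo sapiens) for antiproliferative activity, read by MTT assay, with a stated time of 48 h (a higher number here means a weaker inhibitor of growth, a lower number a stronger inhibitor of growth), compound 1 `COc1cc(/C=C2\Cc3cc(OC)c(OC)c(OC)c3C2=O)cc(OC)c1OC` gives only a limit, > 10000 nM. Compound 2 `COc1cc2c(cc1O)C(=O)/C(=C/c1ccc(OC)c(OC)c1OC)C2` gives a measured value of 1590 nM. Compound 3 `COc1cc2c(cc1OC)C(=O)/C(=C/c1cc(OC)c(OC)c(OC)c1)C2` differs from compound 1 by hydrogen in place of methoxy on an aromatic carbon. For the measured compounds named here, no measured step between two compounds shows what this change does. The expected step of an at least 1.4-fold lower number from compound 1 to compound 3 (0.15 log units; that floor lies within the scatter) is therefore modest, toward stronger inhibition of growth, and may not clear the limit. For compound 3 the estimated value in this assay is 7000 nM, with an expected range of 2000 nM to 25000 nM.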

Compound 3, concentration for 50% growth inhibition: > 10000 nM
Compound 3 gave a limit, no number (the forecaster's own chance of this, stated with the estimate: 45%); at least 1.4-fold (0.15 log units) between middle value and limit.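

For the compounds shown here, compound 1 and compound 3 both give only a limit in this assay, so no step between them can be read: the limit of > 10000 nM in this assay, at which 2 of the 3 values shown sit. The compounds shown leave open whether hydrogen in place of methoxy on this aromatic carbon changes growth inhibition at all.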